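Fluoro for butoxy on a shared core: an expectation

The source may report more compounds than this note shows. Statements on the series, on what has been measured and on what is new or still open speak of the compounds shown alone.

Measured so far:
compound 1, `CCCCOc1ccc(Nc2nc3nonc3nc2O)cc1`: 3700 nM
compound 2, `Cc1cc(OC(F)(F)F)ccc1Nc1nc2nonc2nc1O`: 4600 nM

Two compounds on a shared core have been characterised in an assay on mitochondria from L6 cells (Rattus norvegicus) for activation, with a stated time of 90 min; on this read-out higher numbers stand for an effect only at larger amounts of compound and lower numbers for an effect already at smaller amounts. Compound 1, `CCCCOc1ccc(Nc2nc3nonc3nc2O)cc1`, gives 3700 nM in this assay, and compound 2, `Cc1cc(OC(F)(F)F)ccc1Nc1nc2nonc2nc1O`, gives 4600 nM. For the measured compounds named here, compound 1 carries the lowest of the two numbers, yet its nearest neighbour, compound 2, lies within the scatter of repeated measurement, so the two values cannot be told apart with confidence, and no step between them is drawn.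

Compound 3, `Oc1nc2nonc2nc1Nc1ccc(F)cc1`, has not yet been measured in this assay. Relative to compound 1 it carries fluoro in place of butoxy on an aromatic carbon. The change removes most of the group standing para to the large group and leaves a single atom in its place. Going by the values given here, with only two measured compounds, and no pair differing in one place, the data give no direct guide to the size of such a change.

An estimate for compound 3 is nonetheless offered here. Compound 3 is expected to show a modest step toward a higher number, a 2.2-fold higher number from compound 1 to compound 3 (0.33 log units; beyond the scatter), in this assay. The estimated value for compound 3 is 8000 nM, with a range from 2500 nM to 30000 nM, pending measurement.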

Compound 3, half-maximal effective concentration: 38600 nM
Beside the measured number, compound 3's estimate is 4.8-fold (0.68 log units) below it; the whole stated range lies below it.
By their numbers in this assay, from the lowest: compounds 1 and 2 (each within the scatter of the next); then compound 3.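

In this assay, for the compounds shown here, fluoro in place of butoxy on an aromatic carbon, para to a large group, gives the first step on the shared core that can be read at a single place: a 10-fold higher number from compound 1 to compound 3 (1.02 log units; beyond the scatter), a large step beyond the scatter. The earlier values could not show this, as compound 1 and compound 2 differ in more than one place; the new step shows that the read-out responds strongly to the group at this position, with an effect needing much larger amounts of compound once butoxy gives way to fluoro. Nothing available here accounts for the size of this step.

What the compounds shown leave open is which part of butoxy goes with the lower number, the oxygen attached to the ring or the four-carbon chain, as the change to fluoro replaces both at once. A butyl chain with no oxygen, a shorter methoxy, a longer hexyloxy chain or an amine at this same place would each help to separate these possibilities, and would show whether the number moves gradually or abruptly from one group to the next.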